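Swapping an isopropoxy for bromo on a shared chromone core

The source may hold more compounds than are shown below. What is called first, only, known or untested is meant among the compounds shown, and "the series" means these compounds.

Measured compounds:
compound 1, `CC(C)C(=O)Oc1ccc2oc(/C=C/[S+](C)[O-])cc(=O)c2c1`, 9100 nM
compound 2, `C[S+]([O-])/C=C/c1cc(=O)c2cc(F)ccc2o1`, 7000 nM
compound 3, `CC(C)Oc1ccc2oc(/C=C/[S+](C)[O-])cc(=O)c2c1`, 8000 nM

These three values come from a functional assay on DLD-1 cells (Homo sapiens) for cytotoxicity, with a stated time of 48 h; on this read-out higher numbers stand for weaker inhibition and lower numbers for stronger inhibition. Within the data shown here, compound 3 has the second highest of the three numbers, yet its steps to both neighbours, a 1.1-fold lower number from compound 1 to compound 3 (0.06 log units; within the scatter) and a 1.1-fold higher number from compound 2 to compound 3 (0.06 log units; within the scatter), are within the scatter, so no compound stands apart from the others.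

Compound 4, `C[S+]([O-])/C=C/c1cc(=O)c2cc(Br)ccc2o1`, is not yet measured. It differs from compound 3 in one place: bromo in place of isopropoxy on an aromatic carbon. The step that bears most on it is the change from fluoro to isopropoxy, a 1.1-fold higher number from compound 2 to compound 3 (0.06 log units; within the scatter), which did not move the number beyond the scatter; bromo, like fluoro, is a halogen at the same place. A step of similar size is therefore expected, a 1.1-fold lower number from compound 3 to compound 4 (0.03 log units; within the scatter), in no clear direction.

For compound 4 the expected value in this assay is 7500 nM, within 3500 nM to 16000 nM.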

Compound 4, half-maximal inhibitory concentration: 4500 nM
The estimate for compound 4 lay 1.7-fold (0.22 log units) above the measured number; measured number inside the range.
By their numbers in this assay, from the lowest: compounds 4, 2, 3 and 1 (each within the scatter of the next, the first and the last beyond it).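

Among these compounds, at this place on the aromatic ring, bromo gives the only step beyond the scatter so far in this assay (a 2.0-fold lower number from compound 1 to compound 4 (0.31 log units; beyond the scatter)), though that step is modest. Its steps against the other two groups stay within the scatter (a 1.8-fold lower number from compound 3 to compound 4 (0.25 log units; within the scatter); a 1.6-fold lower number from compound 2 to compound 4 (0.19 log units; within the scatter)), so bromo is not set apart from isopropoxy or fluoro. Nothing measured here gives a reason for the step from the (isopropylcarbonyl)oxy group to bromo. Going by these compounds, it remains open whether iodo, an amine or a carboxylic acid at this place would move the number further from these values.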